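The source may hold more compounds than are shown below. What is called first, only, known or untested is meant among the compounds shown, and "the series" means these compounds.

In a functional assay on PC-9 cells (Homo sapiens) for inhibition, read by MTT assay, with a stated time of 48 h, tested at 10 uM (on this read-out higher numbers stand for more inhibition at the one concentration tested (going by the name of the read-out) and lower numbers for less inhibition), compound 1 `COc1cc(NC(=O)Nc2cc(Nc3ccc(C)c(C)c3)ncn2)cc(OC)c1` gives 66%, the lower of the two numbers reported so far, while compound 2 `COc1ccc(C(F)(F)F)cc1Nc1cc(NC(=O)Nc2c(Cl)cccc2Cl)ncn1` gives 89%, a gap from compound 1 that exceeds the usual scatter. Within the data shown here, compound 2 differs from compound 1 in more than one place at once, so the two values show only that the pair spans a sizeable range; no single change can be read off from them. Compound 3 `COc1cc(NC(=O)Nc2cc(Nc3cc(Br)ccc3OC)ncn2)cc(OC)c1` has not yet been measured. It differs from compound 1 in one place: 5-bromo-2-methoxyphenyl in place of 3,4-dimethylphenyl on a nitrogen on an aromatic ring. Among the measured compounds shown here, nothing among the measured pair shows how this exchange plays out, and the expected step therefore rests on little. The step of a number 4 percentage points lower from compound 1 to compound 3 (within the scatter) is expected to stay within the usual scatter, with no clear direction. Compound 3 is thus estimated at 62%, within a range from 38% to 84%.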

Compound 3, a percentage reported as inhibition, at one concentration (the size of the read-out at that concentration, not a potency): 82.5%
For compound 3 the middle estimate is 20.5 percentage points below the measured one, and the stated range covers the measured number.
By their numbers in this assay, from the lowest: compound 1; then compounds 3 and 2 (each within the scatter of the next).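

In this assay, among these compounds, putting 5-bromo-2-methoxyphenyl in place of 3,4-dimethylphenyl on a nitrogen on an aromatic ring gives a number 16.5 percentage points higher from compound 1 to compound 3 (beyond the scatter), a modest step and the first single change that can be read. It shows that the aromatic group on this nitrogen can be exchanged without loss of inhibition at the one concentration tested, and that here the exchange goes with a higher number. Nothing available explains this step.

The exchange removes both methyl groups and brings in a bromine and a methoxy group together, so the compounds shown cannot say which of these changes accounts for the step. They also leave open how the number would respond to a lone methoxy group, a lone bromine, or a morpholine or carboxylic acid on this aromatic ring.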